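The compounds below may be only part of what the source reports. "The series", "measured", "known", "first", "only" and "open" are said of these compounds alone.

In a toxicity assay on NIH3T3 cells (Mus musculus) for cytotoxicity, read by resazurin assay (a lower number here means that less compound is needed, a higher number that more compound is needed for the effect), compound 1 (`COC(=O)c1ccc(NCc2cncn2Cc2ccccc2Cl)cc1-c1ccccc1`) gives 10000 nM as its half-maximal effective concentration. Compound 2 (`COC(=O)c1ccc(NCc2cncn2Cc2cccc(-c3ccccc3)c2)cc1-c1ccccc1`) has no single number to stand on, with "not determined" (no result reported) as its entry. Compound 3 (`COC(=O)c1ccc(NCc2cncn2Cc2cccc(C(C)(C)C)c2)cc1-c1ccccc1`) has not yet been measured. The structural change is tert-butyl in place of phenyl on an aromatic carbon and amounts to tert-butyl in place of phenyl on an aromatic carbon. Among the compounds with values here, with no measured step to draw on, no step beyond the scatter is expected in this assay in either direction, and compound 1 at 10000 nM remains the only reference. Compound 3 is estimated at 10000 nM with an expected range from 3000 nM to 30000 nM overall.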

Compound 3, half-maximal effective concentration: > 1000 nM
Compound 3: a limit, no number; the forecaster's own chance of this, stated with the estimate: 35%; the middle value is on the limit's open side.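

In this assay compound 3 gives only a limit, > 1000 nM, so no step can be read from compound 1 to compound 3. The compounds shown leave open whether these two differ at all, and how tert-butyl compares with phenyl.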